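This account rests on a few compounds, and the source may have more. Where it says the series, first, only, none or still open, it means among the compounds named here.

Compound 1 `Nc1nn(C(=O)Nc2ccc(Cc3ccccc3)cc2)c2ccccc12` and compound 2 `Nc1nn(C(=O)Nc2ccc(Cc3ccccc3)cc2)c2ccc(Cl)cc12` share one core and differ at a single aromatic carbon. In a functional assay on ACHN cells (Homo sapiens) for antiproliferative activity, read by sulforhodamine B assay, with a stated time of 48 h (on this read-out lower numbers stand for stronger inhibition of growth and higher numbers for weaker inhibition of growth), compound 1 gives 1690 nM, while compound 2 gives 46.8 nM. The step of a 36-fold lower number from compound 1 to compound 2 (1.56 log units; beyond the scatter) is chloro in place of hydrogen on an aromatic carbon. Among the compounds with values here, compound 2 thus holds the lowest number of the two measured so far, with compound 1 far above it. Compound 3 `Nc1ccc2c(c1)c(N)nn2C(=O)Nc1ccc(Cc2ccccc2)cc1` keeps that carbon occupied but changes the group: amino in place of chloro on an aromatic carbon. Within the data shown here, only the step from compound 1 to compound 2 bears on this change, and it was large; it shows that a group on this carbon matters, but not whether an amino group acts like a chloro. The expectation is a rise toward weaker inhibition, as an 11-fold higher number from compound 2 to compound 3 (1.03 log units; beyond the scatter), smaller than the loss of the chloro altogether. For compound 3 the expected value is 500 nM, with a likely range from 100 nM to 3000 nM.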

Compound 3, concentration for 50% growth inhibition: 3370 nM
Compound 3: the middle estimate sits 6.7-fold (0.83 log units) below what was measured; measured number outside the range, above it.
By their numbers in this assay, from the lowest: compound 2; then compounds 1 and 3 (each within the scatter of the next).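

In this assay the change from chloro to amino gives a 72-fold higher number from compound 2 to compound 3 (1.86 log units; beyond the scatter) and so removes the whole gain seen with chloro, which means that simply having a group on this aromatic carbon is not enough. Against the compound with hydrogen at this place, the amino group gives a 2.0-fold higher number from compound 1 to compound 3 (0.30 log units; within the scatter) and leaves compound 3 indistinguishable from compound 1, so among these three compounds the benefit belongs to chloro alone. Nothing on hand explains the gap between chloro and amino.

From the compounds shown here alone, whether other small groups, such as fluoro, bromo, methyl or methoxy, would behave like chloro or like amino remains open. Also open, going by these compounds, is whether chloro would bring a similar gain on the other carbons of this ring.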